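The compounds below may be only part of what the source reports. "The series", "measured", "known", "first", "only" and "open" are said of these compounds alone.

Compound 1, `Cc1cc(C)cc(S(=O)(=O)c2c(C(=O)NC(C)C(=O)NCc3ccco3)[nH]c3ccc(Cl)cc23)c1`: in an ADME assay on MT4 cells (Homo sapiens) for cytotoxicity, read by MTT assay (a higher number here means that more compound is tolerated, a lower number that less compound is tolerated), compound 1 gives 24200 nM.
Compound 2, `Cc1cc(C)cc(S(=O)(=O)c2c(C(=O)NC(C)C(=O)NC(C)c3ccccc3F)[nH]c3ccc(Cl)cc23)c1`: in this assay compound 2 gives 15200 nM.

Compound 2 holds the lowest of the two numbers shown in this assay; its nearest neighbour is compound 1, and the step of a 1.6-fold lower number from compound 1 to compound 2 (0.20 log units; within the scatter) lies within the scatter, so the two compounds cannot be told apart on this read-out. Compound 3, `Cc1cc(C)cc(S(=O)(=O)c2c(C(=O)NC(C)C(=O)NC(C)c3ccncc3)[nH]c3ccc(Cl)cc23)c1`, is not yet measured. It differs from compound 2 in one place: pyridin-4-yl in place of 2-fluorophenyl on a saturated chain carbon bound to an amide-type nitrogen and a saturated chain carbon. Among the compounds with values here, the only measured step, a 1.6-fold lower number from compound 1 to compound 2 (0.20 log units; within the scatter), exchanges one aromatic group for another on the amide-type nitrogen and produced no change beyond the scatter. Within the data shown here, no measured step touches the exchange of 2-fluorophenyl for pyridin-4-yl itself, so nothing in the data points to a move in either direction. The step from compound 2 to compound 3 is therefore expected to stay within the scatter, a 1.1-fold higher number from compound 2 to compound 3 (0.02 log units; within the scatter). Compound 3 is estimated to give 16000 nM in this assay, with a range from 6000 nM to 45000 nM.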

Compound 3, half-maximal cytotoxic concentration: 21900 nM
Compound 3: middle estimate off by 1.4-fold (0.14 log units), on the low side; the measured number falls inside the stated range.
By their numbers in this assay, from the lowest: compounds 2, 3 and 1 (each within the scatter of the next).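

In this assay the exchange of 2-fluorophenyl for pyridin-4-yl on a saturated chain carbon bound to an amide-type nitrogen and a saturated chain carbon gives a 1.4-fold higher number from compound 2 to compound 3 (0.16 log units; within the scatter) and so does not separate the two compounds, even though the entering ring carries a hetero atom and a hydrogen-bond acceptor that the leaving ring lacks. The exchange of (furan-2-yl)methyl for 1-(pyridin-4-yl)ethyl on the amide-type nitrogen gives a 1.1-fold lower number from compound 1 to compound 3 (0.04 log units; within the scatter) and likewise stays inside the scatter, so the furan, fluorophenyl and pyridine variants shown here cannot be told apart on this read-out. Nothing available bears on why these numbers lie so close together.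

On these data alone, all three compounds carry an aromatic ring at this end of the molecule, so it remains open whether a group of another kind there, such as a carboxylic acid, a piperidine or a longer alkyl chain, would move the number beyond the scatter. As far as these compounds go, it also remains open whether the same tolerance would hold with a change elsewhere in the shared core.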